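Amide-side substituent changes and the antiproliferative readout

The source may hold more compounds than are shown below. What is called first, only, known or untested is meant among the compounds shown, and "the series" means these compounds.

Going by the values given here, compound 1 `CCn1c(C(=O)NCCCN(C)C)ccc1C(CC)(CC)c1ccc(OCCC(O)(CC)CC)c(C)c1` gives 2420 nM in an ADME assay on L02 cells (Homo sapiens) for antiproliferative activity, read by MTT assay, with a stated time of 48 h (a higher number here means a weaker inhibitor, a lower number a stronger inhibitor), the second highest of the three numbers measured so far. Compound 2 `C=CCN(C)C(=O)c1ccc(C(CC)(CC)c2ccc(OCCC(O)(CC)CC)c(C)c2)n1CC` gives 1190 nM, and compound 3 `CCOC(=O)C(CC(=O)OC)NC(=O)c1ccc(C(CC)(CC)c2ccc(OCCC(O)(CC)CC)c(C)c2)n1CC` gives 4280 nM. The measured steps are a 2.0-fold lower number from compound 1 to compound 2 (0.31 log units; beyond the scatter), a 1.8-fold higher number from compound 1 to compound 3 (0.25 log units; within the scatter) and a 3.6-fold higher number from compound 2 to compound 3 (0.56 log units; beyond the scatter). Compound 4 `CCn1c(C(=O)NC(C)C(=O)O)ccc1C(CC)(CC)c1ccc(OCCC(O)(CC)CC)c(C)c1` differs from compound 1 by 1-carboxyethyl in place of 3-(dimethylamino)propyl on an amide-type nitrogen. Among the compounds with values here, the closest precedent is the step from compound 1 to compound 3, where the 3-(dimethylamino)propyl group likewise left the amide-type nitrogen and a larger group entered, moving within the scatter toward a higher number; the step from compound 2 to compound 3 points the same way. A modest rise at most is therefore expected. Compound 4 is estimated at 3400 nM, within 1500 nM to 8000 nM. This expectation amounts to a 1.4-fold higher number from compound 1 to compound 4 (0.15 log units; within the scatter).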

Compound 4, half-maximal inhibitory concentration: 4040 nM
Estimate against measurement, compound 4: 1.2-fold (0.07 log units) below; measured number inside the range.
By their numbers in this assay, from the lowest: compound 2; then compounds 1, 4 and 3 (each within the scatter of the next).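

In this assay the 1-carboxyethyl group on the amide-type nitrogen stays within the scatter of the 3-(dimethylamino)propyl group it replaces (a 1.7-fold higher number from compound 1 to compound 4 (0.22 log units; within the scatter)). It also stays within the scatter of the larger group on compound 3 (a 1.1-fold lower number from compound 3 to compound 4 (0.03 log units; within the scatter)), so a free carboxylic acid at this position reads no differently from either. Only compound 2, with its allyl(methyl)amino group, separates from this set (a 3.4-fold higher number from compound 2 to compound 4 (0.53 log units; beyond the scatter)).

Open, as far as these compounds go, is how a longer chain carrying a carboxylic acid, or a cyclic amine such as piperidine on the carbonyl carbon, would read. No measured evidence bears on what lies behind these numbers.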